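The source may hold more compounds than are shown below. What is called first, only, known or untested is meant among the compounds shown, and "the series" means these compounds.

Compound 1 `C=CCN1CCC(c2noc(COc3ccc(/C=C/C(=O)NO)cc3)n2)CC1`: 66%
Compound 2 `O=C(/C=C/c1ccc(OCc2nc(C3CCN(Cc4cccc(F)c4)CC3)no2)cc1)NO`: 73%

Both were tested in an assay on isolated protein for inhibition of protein deacetylase HDAC6 (Homo sapiens), read by fluorescence, with a stated time of 1 h, tested at 100 nM; a higher number here means more inhibition at the concentration tested (going by the name of the read-out), a lower number less inhibition. Among the measured compounds shown here, compound 2 stands level with compound 1 there, the only step measured, a number 7 percentage points higher from compound 1 to compound 2 (within the scatter), lying within the scatter. Compound 3 `O=C(/C=C/c1ccc(OCc2nc(C3CCN(Cc4ccc(Br)cc4)CC3)no2)cc1)NO` differs from compound 2 in one place: 4-bromophenyl in place of 3-fluorophenyl on a saturated chain carbon bound to an amine nitrogen in a ring. For the measured compounds named here, the sole step that bears on this change is a number 7 percentage points higher from compound 1 to compound 2 (within the scatter), which altered the same place and did not move this assay beyond the scatter, so the expected step of a number 3 percentage points lower from compound 2 to compound 3 (within the scatter) is likewise not beyond the scatter. Compound 3 is therefore estimated at 70%, expected between 52% and 88%.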

Compound 3, a percentage reported as inhibition, at one concentration (the size of the read-out at that concentration, not a potency): 58%
Compound 3: middle estimate off by 12 percentage points, on the high side; the range from low to high includes it.
By their numbers in this assay, from the lowest: compounds 3, 1 and 2 (each within the scatter of the next, the first and the last beyond it).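

Swapping 3-fluorobenzyl for 4-bromobenzyl on the ring amine nitrogen gives, in this assay, a number 15 percentage points lower from compound 2 to compound 3 (beyond the scatter), so this position can separate two halogenated aryl groups. Against the vinyl group, the 4-bromophenyl group gives a number 8 percentage points lower from compound 1 to compound 3 (within the scatter), so neither aryl group stands clear of vinyl. No measurement available explains the step.

Because halogen and ring placement change together, the compounds shown cannot say which of them carries the step. A 4-fluorobenzyl or 3-bromobenzyl group at this nitrogen would separate the two, and an unsubstituted benzyl group would show what either halogen adds.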